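A few compounds are considered here, and "the series" means these few. Any claim that something is new, unique, unknown or untested is made for them only; others in the source may bear on it.

Measured so far:
compound 1, `CN/C(=N\CCC(c1ccc(Br)cc1)c1ccccn1)NCCCc1c[nH]cn1`, 5.71 in a functional assay on ileum for antagonist activity at histamine H1 receptor (Cavia porcellus); a lower number here means a less potent compound, a higher number a more potent compound, by a factor of ten per unit of this negative logarithm
compound 2, `Brc1ccc(C(CC/N=C(/NCCCc2c[nH]cn2)NC2CCCCC2)c2ccccn2)cc1`, 5.42 in this assay
compound 3, `CN/C(=N\CCCC(c1ccc(Cl)c(Cl)c1)c1ccccn1)NCCCc1c[nH]cn1`, 6.16 in this assay

Compound 1 and compound 2 differ only by cyclohexyl in place of methyl on an amine nitrogen; the step seen is a number 0.29 log units lower from compound 1 to compound 2 (within the scatter). Compound 3 carries a different core from compound 1; the difference between the two cores is not broken down here. Compound 3 gives the highest number of the three, beyond the scatter from both compound 1 and compound 2.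

Compound 4, `Clc1ccc(C(CCC/N=C(/NCCCc2c[nH]cn2)NC2CCCCC2)c2ccccn2)cc1Cl`, is not yet measured. It differs from compound 3 by cyclohexyl in place of methyl on an amine nitrogen, the same change as from compound 1 to compound 2, at the same place. The expectation for compound 4 in this assay rests on that earlier step: a step of about a number 0.26 log units lower from compound 3 to compound 4 (within the scatter) is expected, beside a number 0.29 log units lower from compound 1 to compound 2 (within the scatter). Compound 4 is therefore estimated at 5.9, within 5.4 to 6.4.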

Compound 4, negative logarithm of the antagonist equilibrium constant: 5.76
The estimate for compound 4 lay 0.14 log units above the measured number, within the range that was stated.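

In this assay, cyclohexyl in place of methyl on the amine nitrogen gives a number 0.40 log units lower from compound 3 to compound 4 (beyond the scatter). Set beside the earlier step, the change carries over between the two cores: the same change on two cores in this assay, a number 0.29 log units lower (within the scatter) from compound 1 to compound 2 and a number 0.40 log units lower (beyond the scatter) from compound 3 to compound 4, 0.11 log units apart, within the scatter of two such steps. This agreement rests on two cores only; it says nothing about any further core and gives no reason for the step.

Open, on these data alone, is whether other groups on this amine nitrogen, such as ethyl, benzyl or phenyl, would follow the same course between these cores. Also open, as far as these compounds go, is how much of the gap between the core of compound 1 and the core of compound 3 belongs to the chain and how much to the halogens on the ring, as these two compounds differ in more than one place.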